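A few compounds are considered here, and "the series" means these few. Any claim that something is new, unique, unknown or untested is made for them only; others in the source may bear on it.

Measured so far:
- compound 1 `COc1ccc(S(=O)(=O)N2CCc3cccc(-c4ccco4)c32)cc1`: 42 nM
- compound 2 `COc1ccc(S(=O)(=O)N2CCc3cccc(-c4ccc(F)c(F)c4)c32)cc1`: 55.5 nM

In a functional assay on MKN-45 cells (Homo sapiens) for inhibition, with a stated time of 72 h (a lower number here means a stronger inhibitor, a higher number a weaker inhibitor), compound 1 gives 42 nM and compound 2 gives 55.5 nM. Within the data shown here, these are the only two numbers available, and they cannot be told apart: the step between them is a 1.3-fold higher number from compound 1 to compound 2 (0.12 log units; within the scatter). Compound 1 therefore stands level with compound 2.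

Compound 3 `COc1ccc(S(=O)(=O)N2CCc3cccc(-c4ccc(F)cc4)c32)cc1` has not yet been measured. It departs from compound 1 as follows: 4-fluorophenyl in place of furan-2-yl on an aromatic carbon. In words, 4-fluorophenyl stands in place of furan-2-yl on an aromatic carbon, and the rest of the structure is shared.

Among the measured compounds shown here, only one measured step bears on this change. In compound 2, 3,4-difluorophenyl replaces the same furan-2-yl, and that exchange gave a 1.3-fold higher number from compound 1 to compound 2 (0.12 log units; within the scatter). Compound 3 carries one fluorine-bearing phenyl group of the same kind, so no shift beyond the scatter is expected in this assay, though this rests on a single step. The expected step is a 1.2-fold higher number from compound 1 to compound 3 (0.08 log units; within the scatter). For compound 3 the estimated value is 50 nM, with an expected range from 20 nM to 125 nM.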

Compound 3, half-maximal inhibitory concentration: 79 nM
Beside the measured number, compound 3's estimate is 1.6-fold (0.20 log units) below it; the range from low to high includes it.
By their numbers in this assay, from the lowest: compounds 1, 2 and 3 (each within the scatter of the next).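

In this assay, 4-fluorophenyl in place of furan-2-yl on this aromatic carbon gives a 1.9-fold higher number from compound 1 to compound 3 (0.27 log units; within the scatter) and thus a second exchange of the five-membered aromatic ring for a fluorine-bearing phenyl group that stays within the scatter. Hydrogen in place of fluoro gives a 1.4-fold higher number from compound 2 to compound 3 (0.15 log units; within the scatter) and adds the first direct comparison of the two phenyl groups, which cannot be told apart here, so the three groups shown at this place all give numbers that lie within the scatter of one another. There is no measured information on why these numbers fall as they do.

All three compounds carry an aromatic ring at this carbon, so the compounds shown leave open how this place responds to a group of another kind, such as an amine, a carboxylic acid or a longer alkyl chain. They also leave open how a phenyl ring bearing a nitrile or a trifluoromethyl group would compare with the 4-fluorophenyl group of compound 3.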